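The source may report more compounds than this note shows. Statements on the series, on what has been measured and on what is new or still open speak of the compounds shown alone.

Among the measured compounds shown here, in a functional assay on WiDr cells (Homo sapiens) for inhibition (a higher number here means a weaker inhibitor, a lower number a stronger inhibitor), compound 1 `CCOC(=O)c1ccc(NC(=O)N2CC2C#N)cc1` gives 4200 nM, the lower of the two numbers measured so far. The other measured compound, compound 2 `N#CC1CN1C(=O)Nc1ccc(Cl)c(Cl)c1`, gives 14000 nM in this assay, a higher number that lies beyond the usual scatter. For the measured compounds named here, these two compounds differ in more than one place, so the pair shows only that compound 1 is the stronger inhibitor of the two and offers no single isolated step.

Compound 3 `N#CC1CN1C(=O)Nc1ccc(S(N)(=O)=O)cc1` has not yet been measured. It differs from compound 1 in one place: sulfamoyl in place of ethoxycarbonyl on an aromatic carbon. Going by the values given here, no measured pair in this set isolates such an exchange, so there is no step to lean on, and the expectation rests on the change itself and on where compound 1 stands.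

The step expected is a 1.4-fold higher number from compound 1 to compound 3 (0.15 log units; within the scatter), a modest one, if anything toward a weaker inhibitor, and likely close to the scatter. On that basis compound 3 is estimated at 6000 nM in this assay, with a range from 2000 nM to 20000 nM.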

Compound 3, half-maximal inhibitory concentration: > 38000 nM
Compound 3 gave a limit, no number; the forecaster's own chance of this, stated with the estimate: 10%; middle value at least 6.3-fold (0.80 log units) away from the limit.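

Among the compounds shown here, the position carrying ethoxycarbonyl is not indifferent to what sits there: sulfamoyl in its place on the aromatic carbon gives an at least 9.0-fold higher number from compound 1 to compound 3 (0.95 log units; beyond the scatter), the first step in this set that isolates a single place. In this assay compound 3 stands only as a limit, > 38000 nM, and not as a number, so the step has a lower bound but no known size. The group that enters carries a hydrogen-bond donor and the group that leaves carries none, and the two differ little in heavy atoms, yet this one exchange takes compound 3 to the end of the range shown: the limit of > 38000 nM in this assay, at which 1 of the 3 values shown sits.

One exchange cannot separate what the loss of ethoxycarbonyl contributes from what the arrival of sulfamoyl contributes, and compound 2 differs from compound 1 in more than one place, so it cannot help to settle this. The compounds shown leave open how a carboxylic acid, a primary carboxamide, a methylsulfonyl group or a sulfamoyl group with methyl on its nitrogen would read on the same aromatic carbon.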